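Compound 4: azetidin-3-yl in place of pyrrolidin-2-yl

A few compounds are considered here, and "the series" means these few. Any claim that something is new, unique, unknown or untested is made for them only; others in the source may bear on it.

Measured so far in an assay for inhibition of Indoleamine 2,3-dioxygenase 1 (Homo sapiens), with stated times of 10 min and 60 min, tested at 10 uM; a lower number here means a weaker effect, a higher number a stronger effect of the compound at the concentration tested:
compound 1, `Oc1ccc(CNc2cc(C(F)(F)F)cc3[nH]ncc23)cc1`, 37%
compound 2, `FC(F)(F)c1cc(NC[C@H]2CCCN2)c2cn[nH]c2c1`, 34%
compound 3, `O=[N+]([O-])c1cc(Br)c(F)cc1CNc1cc(C(F)(F)F)cc2[nH]ncc12`, 31%

Compound 2 sits second of the three numbers in this assay, but both neighbours lie within the scatter of it: compound 1 is nearest, compound 3 furthest, and neither gap is beyond the scatter, so the three compounds are not separable on these numbers.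

The step to the unmeasured compound 4, `FC(F)(F)c1cc(NCC2CNC2)c2cn[nH]c2c1`, changes the group on the saturated chain carbon bound to the nitrogen on the aromatic ring: azetidin-3-yl in place of pyrrolidin-2-yl on a saturated chain carbon bound to a nitrogen on an aromatic ring

Among the measured compounds shown here, one measured step bears on this place. The change a number 3 percentage points lower from compound 1 to compound 2 (within the scatter) swapped 4-hydroxyphenyl for pyrrolidin-2-yl at the same saturated chain carbon, and the number barely moved. The three measured compounds carry quite different groups at this carbon and all land within the scatter of one another, so the site looks tolerant to what is attached there. For the measured compounds named here, no measured step addresses a four-membered ring or a shift of the attachment point within the ring, so the expectation rests on that tolerance alone.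

Compound 4 is therefore expected to give 34% in this assay, with a range from 22% to 46%. The expected step of no change at the digits printed from compound 2 to compound 4 (within the scatter) is no change beyond the scatter.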

Compound 4, a percentage reported as inhibition, at one concentration (the size of the read-out at that concentration, not a potency): 10%
For compound 4 the middle estimate is 24 percentage points above the measured one; measured number outside the range, below it.
By their numbers in this assay, from the lowest: compound 4; then compounds 3, 2 and 1 (each within the scatter of the next).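

In this assay, among the compounds shown here, this place on a saturated chain carbon bound to a nitrogen on an aromatic ring proves less forgiving than the earlier compounds suggested: azetidin-3-yl in place of pyrrolidin-2-yl gives a number 24 percentage points lower from compound 2 to compound 4 (beyond the scatter). Azetidin-3-yl also separates from the 4-hydroxyphenyl group, with a number 27 percentage points lower from compound 1 to compound 4 (beyond the scatter), whereas the swap between 4-hydroxyphenyl and pyrrolidin-2-yl stayed small, with a number 3 percentage points lower from compound 1 to compound 2 (within the scatter). The drop therefore comes from a change that keeps the counts of hydrogen-bond donors and acceptors and the absence of net charge, while the ring goes from five-membered to four-membered, the attachment point moves, and the defined stereocentre is lost.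

Nothing shown gives a reason for this drop. The compounds shown leave open which of those three differences carries the step, something that azetidin-2-yl and pyrrolidin-3-yl groups, along with the opposite stereoisomer of compound 2, could begin to separate, and whether a larger piperidin-4-yl ring or an open-chain aminoethyl group would sit with compound 2 or with compound 4.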